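A few compounds are considered here, and "the series" means these few. Any claim that something is new, unique, unknown or untested is made for them only; others in the source may bear on it.

The shared core of compound 1 `CS(=O)(=O)Oc1c(C(=O)NCc2ccc(F)cc2)nc(Br)c2cccnc12` carries a (methylsulfonyl)oxy group, and in a functional assay on MDA-MB-435 cells (Homo sapiens) for cytotoxicity, read by MTT assay, with a stated time of 72 h (on this read-out higher numbers stand for weaker inhibition and lower numbers for stronger inhibition), compound 1 gives only a limit of > 20000 nM, which is a limit and not a number (the limit of > 20000 nM in this assay, at which 1 of the 3 values shown sits). Two other compounds sit on the same core but differ from compound 1 in more than one place: compound 2 `N[C@H]1CC[C@H](Nc2c(C(=O)NCc3ccccn3)nc(Br)c3cccnc23)CC1` gives 4000 nM in this assay, and compound 3 `N[C@H]1CC[C@H](Nc2c(C(=O)NCc3ccc(Cl)cc3Cl)nc(Br)c3cccnc23)CC1` gives 5800 nM. Among the measured compounds shown here, the only measured step between neighbours, a 1.5-fold higher number from compound 2 to compound 3 (0.16 log units; within the scatter), concerns a change on a saturated chain carbon bound to an amide-type nitrogen and does not touch the change that leads to compound 4.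

Compound 4 `O=C(NCc1ccc(F)cc1)c1nc(Br)c2cccnc2c1N1CCNCC1` is obtained from compound 1 by piperazin-1-yl in place of (methylsulfonyl)oxy on an aromatic carbon. For the measured compounds named here, no measured step bears on this replacement, so the expectation rests on the standing of compound 1 as a limit and on the values of compound 2 and compound 3, which are the only numbers on this core. It is estimated that compound 4 reaches a measurable value in this assay, expected at 7000 nM within a range from 2500 nM to 20000 nM. The expected change from the limit of compound 1 is therefore an at least 2.8-fold lower number from compound 1 to compound 4 (0.45 log units; beyond the scatter).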

Compound 4, half-maximal inhibitory concentration: 8000 nM
Compound 4: the middle estimate sits 1.1-fold (0.06 log units) below what was measured; measured number inside the range.
By their numbers in this assay, from the lowest: compounds 2, 3 and 4 (each within the scatter of the next). At a limit, above all of these: compound 1.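

Among the compounds shown here, replacing (methylsulfonyl)oxy with piperazin-1-yl on the aromatic carbon para to a bromo group gives an at least 2.5-fold lower number from compound 1 to compound 4 (0.39 log units; beyond the scatter) in this assay, the first measured step at this position on the shared core. For the compounds shown here, until now, the only step between neighbours concerned a saturated chain carbon bound to an amide-type nitrogen, so this result is the first to show that a change at this aromatic carbon can carry a compound from a limit to a measurable number. Compound 1 still stands at a limit and not at a number, which means the step gives only a minimum size: the limit of > 20000 nM in this assay, at which 1 of the 4 values shown sits.

The compounds shown leave open whether the response depends on the six-membered ring of piperazin-1-yl or on its nitrogen atoms, a question that a morpholin-4-yl ring or an open-chain amine on the same aromatic carbon would address. Compound 4 also differs from compound 2 and compound 3 in more than one place, so the effect of the group at this position cannot be separated from that of the rest of the molecule in those comparisons.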